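The source may report more compounds than this note shows. Statements on the series, on what has been measured and on what is new or still open speak of the compounds shown alone.

Measured so far:
compound 1 `CCc1cccc(NS(=O)(=O)c2ccc(N3CCNC3=O)cc2)c1` gives 130 nM in a functional assay on MCF7 cells (Homo sapiens) for antiproliferative activity, read by sulforhodamine B assay, with a stated time of 48 h; a lower number here means a stronger inhibitor, a higher number a weaker inhibitor
compound 2 `Cc1cccc(NS(=O)(=O)c2ccc(N3CCNC3=O)cc2)c1C` gives 230 nM in this assay

Within the data shown here, compound 2 carries the higher of the two numbers, with compound 1 its only neighbour; the separation, a 1.8-fold higher number from compound 1 to compound 2 (0.25 log units; within the scatter), stays within the scatter, so the two cannot be ranked against each other.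

Compound 3 `COc1cccc(NS(=O)(=O)c2ccc(N3CCNC3=O)cc2)c1` is not yet measured. The change from compound 2 is 3-methoxyphenyl in place of 2,3-dimethylphenyl on a sulfonamide nitrogen. Among the measured compounds shown here, the only step that bears on it is the one from compound 1 to compound 2, likewise an exchange of the aryl group on the sulfonamide nitrogen, and that step was a 1.8-fold higher number from compound 1 to compound 2 (0.25 log units; within the scatter), within the scatter. Nothing in the series shows that an aryl exchange at this position moves the number beyond the scatter. A step of a 1.2-fold lower number from compound 2 to compound 3 (0.08 log units; within the scatter) is therefore expected. Compound 3 is estimated at 190 nM, with a range from 70 nM to 500 nM.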

Compound 3, half-maximal inhibitory concentration: 120 nM
For compound 3 the middle estimate is 1.6-fold (0.20 log units) above the measured one, within the range that was stated.
By their numbers in this assay, from the lowest: compounds 3, 1 and 2 (each within the scatter of the next).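

In this assay the exchange of 2,3-dimethylphenyl for 3-methoxyphenyl on the sulfonamide nitrogen gives a 1.9-fold lower number from compound 2 to compound 3 (0.28 log units; within the scatter) and thus adds a second aryl exchange at this position that stays within the scatter. The entering group counts one hydrogen-bond acceptor where the leaving group counts none, yet compound 2 and compound 3 cannot be ranked against each other. Methoxy in place of ethyl on an aromatic carbon gives a 1.1-fold lower number from compound 1 to compound 3 (0.03 log units; within the scatter) and extends the same reading to the pair that differs only in that group, while no supporting data explain why the three aryl groups stay within the scatter of one another.

From the compounds shown here alone, whether an amine, a carboxylic acid or a longer alkyl chain on the aryl group would move the number beyond the scatter remains open. Also open, going by these compounds, is whether replacing the aryl group on the sulfonamide nitrogen with a saturated ring such as cyclohexyl would preserve the activity.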